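The compounds below may be only part of what the source reports. "The series", "measured", "known", "first", "only" and "open" are said of these compounds alone.

Compound 1, `COc1ccc2c(=O)c(-c3ccccc3)c(-n3ccnc3)oc2c1`, is the reference point. In an assay for inhibition of Aromatase (Homo sapiens) (a lower number here means a stronger inhibitor, a higher number a weaker inhibitor), compound 1 gives 770 nM, the lowest of the two plain numbers in view. Compound 2, `COc1ccc(-c2c(-n3ccnc3)oc3cc(OC)ccc3c2=O)cc1`, gives 2000 nM in this assay, which is a 2.6-fold higher number from compound 1 to compound 2 (0.41 log units; beyond the scatter). Compound 3, `COc1ccc2c(=O)c(-c3ccccc3)c(Sc3ncc[nH]3)oc2c1`, has no plain number at all: in this assay compound 3 reaches only the limit > 50000 nM. That corresponds to an at least 64-fold higher number from compound 1 to compound 3 (1.81 log units; beyond the scatter), and because compound 3 sits at the limit of > 50000 nM in this assay, at which 1 of the 3 values shown sits, the true size of that step is known only as a bound.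

The compound not yet measured is compound 4, `COc1ccc2c(=O)c(-c3ccccc3)c(Sc3nnc[nH]3)oc2c1`. Relative to compound 1 the change is (4H-1,2,4-triazol-3-yl)sulfanyl in place of 1H-imidazol-1-yl on an aromatic carbon. For the measured compounds named here, of the measured steps, only the one from compound 1 to compound 3 bears on this: both exchange the 1H-imidazol-1-yl for a sulfanyl-linked five-membered ring carrying a ring hydrogen, and that exchange gave a large loss, reaching the limit. Compound 4 adds one more ring nitrogen to the same kind of sulfanyl-linked ring, so a similar large loss, quite possibly again ending at a limit, is expected. Compound 4 is therefore estimated at 40000 nM, with a range from 8000 nM to 200000 nM. That estimate would mean a 52-fold higher number from compound 1 to compound 4 (1.72 log units; beyond the scatter).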

Compound 4, half-maximal inhibitory concentration: > 50000 nM
Compound 4 ended at the assay's limit (the forecaster's own chance of this, stated with the estimate: 60%); middle value at least 1.2-fold (0.09 log units) from the limit.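

Putting (4H-1,2,4-triazol-3-yl)sulfanyl in place of 1H-imidazol-1-yl, on the carbon next to the ring oxygen, gives an at least 64-fold higher number from compound 1 to compound 4 (1.81 log units; beyond the scatter) in this assay. The value of compound 4, > 50000 nM, is a limit and not a number. The large loss first seen with compound 3 is therefore not tied to one particular ring, as it appears again with a sulfanyl-linked ring holding one more ring nitrogen, but the step between compound 3 and compound 4 cannot be read because both values stop at the same limit: the limit of > 50000 nM in this assay, at which 2 of the 4 values shown sit.

The compounds shown do not separate the effect of the sulfur link from that of the ring it carries, and a 1,2,4-triazol-1-yl group joined directly to the core, or a simple methylsulfanyl group at the same position, would help to pull the two apart. Also open, from the compounds shown here alone, is how weak compound 3 and compound 4 truly are, and whether the extra ring nitrogen changes the result at all.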